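The compounds below may be only part of what the source reports. "The series", "measured", "known", "first", "only" and "open" are said of these compounds alone.

Working notes on the series. In a functional assay on A549 cells (Homo sapiens) for cytotoxicity, read by MTT assay, with a stated time of 48 h (on this read-out higher numbers stand for weaker inhibition and lower numbers for stronger inhibition), compound 1 `N#Cc1ccc(Cn2cc(COc3ccc4c(=O)ccoc4c3)nn2)cc1` gives only the assay limit, > 100000 nM. Compound 2 `O=c1ccoc2cc(OCc3cn(Cc4cccc(Br)c4)nn3)ccc12` likewise sits at a limit in this assay, > 100000 nM. Compound 3 `C#CCOc1ccc2c(=O)ccoc2c1` also returns only a limit in this assay, > 100000 nM. Going by the values given here, the single step between measured compounds that differ in one place, a step that the two limits leave unreadable from compound 1 to compound 2, is not readable, both of its ends being limits; the only feature of the numbers is the limit of > 100000 nM in this assay, at which 3 of the 3 values shown sit. Compound 2 therefore stands at the limit with no number of its own in this assay.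

Compound 4 `N#Cc1cccc(Cn2cc(COc3ccc4c(=O)ccoc4c3)nn2)c1` differs from compound 2 by cyano in place of bromo on an aromatic carbon. Among the compounds with values here, the one measured step exchanged a 4-cyanophenyl for a 3-bromophenyl and its size is not readable, so the measured steps give no direction for the move from bromo to cyano; no step beyond the scatter is expected in this assay. Compound 4 is expected to give 150000 nM, between 50000 nM and 500000 nM, most probably again only as a limit. The expected step that the limit leaves unreadable from compound 2 to compound 4 is estimated to lie within the scatter.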

Compound 4, half-maximal inhibitory concentration: 14300 nM
Compound 4: middle estimate off by 10-fold (1.02 log units), on the high side; the measured number lies below the stated range.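

In this assay the series now has its first readable steps: cyano in place of bromo on this aromatic carbon gives an at least 6.9-fold lower number from compound 2 to compound 4 (0.84 log units; beyond the scatter), and 3-cyanophenyl in place of 4-cyanophenyl gives an at least 6.9-fold lower number from compound 1 to compound 4 (0.84 log units; beyond the scatter). Both the nature of the group and its place on the ring therefore matter, since neither 3-bromophenyl nor 4-cyanophenyl leaves the limit, while 3-cyanophenyl does. On these data alone, the full size of both steps remains unknown, as each has a limit at one end: the limit of > 100000 nM in this assay, at which 3 of the 4 values shown sit.

As far as these compounds go, whether an amine, a carboxylic acid or a methoxy group at this same ring position would go further than cyano stays open. So does whether the gain from 3-cyanophenyl survives a longer chain between the ring and the aromatic nitrogen.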